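Benzylamide acrylonitriles: pyrrole to chlorofuran in HT-29 cells

The source may hold more compounds than are shown below. What is called first, only, known or untested is meant among the compounds shown, and "the series" means these compounds.

Measured compounds:
compound 1, `N#C/C(=C\c1ccc(Cl)cc1)C(=O)c1ccc[nH]1`: 36000 nM
compound 2, `N#C/C(=C\c1c[nH]c2ccccc12)C(=O)c1c[nH]c2ccccc12`: 6000 nM
compound 3, `COc1ccc(CNC(=O)/C(C#N)=C/c2ccc[nH]2)cc1`: only a limit, > 50000 nM

All three were tested in a functional assay on HT-29 cells (Homo sapiens) for inhibition, read by MTT assay, with a stated time of 72 h; a higher number here means a weaker inhibitor of growth, a lower number a stronger inhibitor of growth. Compound 1 gives 36000 nM. Compound 2 gives 6000 nM in this assay. Compound 3 is different in kind: for compound 3 this assay reports only a limit, > 50000 nM, so no number stands behind it. That puts compound 3 at the weak edge of what this assay shows, alongside the line (the limit of > 50000 nM in this assay, at which 1 of the 3 values shown sits); both other compounds sit at measured numbers.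

Compound 4, `COc1ccc(CNC(=O)/C(C#N)=C/c2ccc(Cl)o2)cc1`, differs from compound 3 in one place: 5-chlorofuran-2-yl in place of 1H-pyrrol-2-yl on a double-bonded chain carbon bound to a double-bonded chain carbon. Among the measured compounds shown here, no pair of measured compounds differing only in this way is available, so the size of the step is open. Since compound 3 stands at a limit, the step from compound 3 to compound 4 can only be estimated: it is expected to run toward stronger inhibition of growth, about an at least 1.2-fold lower number from compound 3 to compound 4 (0.09 log units; that floor lies within the scatter), though a result that again stays at the limit is nearly as likely. Compound 4 is therefore estimated at 40000 nM in this assay, within a range from 12000 nM to 150000 nM.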

Compound 4, concentration for 50% growth inhibition: 9000 nM
Compound 4: the middle estimate sits 4.4-fold (0.65 log units) above what was measured, and the stated range ends above it.
By their numbers in this assay, from the lowest: compounds 2 and 4 (each within the scatter of the next); then compound 1. At a limit, above all of these: compound 3.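

In this assay, among the compounds shown here, 5-chlorofuran-2-yl in place of 1H-pyrrol-2-yl on a double-bonded chain carbon bound to a double-bonded chain carbon brings an at least 5.5-fold lower number from compound 3 to compound 4 (0.74 log units; beyond the scatter), so this place on the chain can move the read-out from the limit to a measured number, a step that the earlier compounds, with no pair differing in one place, could not show. Compound 3 stands only at a limit, > 50000 nM, so the size of the step is a floor and its true size remains unknown: the limit of > 50000 nM in this assay, at which 1 of the 4 values shown sits. The change also does more than one thing at once, since the ring hydrogen-bond donor leaves while a ring oxygen and a chlorine enter, and the single step does not divide among these parts.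

The compounds shown leave open how a plain furan-2-yl without the chlorine, or a 5-chloropyrrol-2-yl, would stand at this place, and so which part of the change carries the step. They also leave open whether the step would hold if a carboxylic acid took the place of the amide on the shared core.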